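From Heptyloxy to Chloro on the Shared Core

A few compounds are considered here, and "the series" means these few. Any claim that something is new, unique, unknown or untested is made for them only; others in the source may bear on it.

Measured in a functional assay on HL-60 cells (Homo sapiens) for cytotoxicity, read by WST assay, with a stated time of 48 h; a lower number here means that less compound is needed, a higher number that more compound is needed for the effect:
- compound 1 (`COc1ccccc1C[C@H]1C(=O)OC[C@@H]1Cc1ccccc1`) gives 79000 nM
- compound 2 (`CCCCCCCOc1ccccc1C[C@H]1C(=O)OC[C@@H]1Cc1ccccc1`) gives 75000 nM

Going by the values given here, compound 2 lies within the scatter of compound 1, the only other compound measured, so the two cannot be ranked. The next structure is compound 3 (`O=C1OC[C@H](Cc2ccccc2)[C@H]1Cc1ccccc1Cl`), with chloro in place of heptyloxy on an aromatic carbon. The change sits on a six-membered aromatic ring of carbon only, ortho to a large group. Among the compounds with values here, one measured step bears on it, because it changes the same substituent: a 1.1-fold lower number from compound 1 to compound 2 (0.02 log units; within the scatter). Within the data shown here, that step altered only the chain on the oxygen, whereas chloro replaces the oxygen as well, and no measured step covers such a swap. With compound 2 at 75000 nM as the starting point, no step beyond the scatter is expected in this assay, in either direction, though this expectation is loosely founded. The expected step is a 1.1-fold lower number from compound 2 to compound 3 (0.03 log units; within the scatter). Compound 3 is estimated at 70000 nM, with an expected range from 30000 nM to 150000 nM.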

Compound 3, half-maximal effective concentration: 37000 nM
Estimate against measurement, compound 3: 1.9-fold (0.28 log units) above; the measured number falls inside the stated range.
By their numbers in this assay, from the lowest: compound 3; then compounds 2 and 1 (each within the scatter of the next).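

In this assay this place on the aromatic ring now proves able to move the number: the change of chain on the oxygen gave only a 1.1-fold lower number from compound 1 to compound 2 (0.02 log units; within the scatter) while chloro in place of heptyloxy gives a 2.0-fold lower number from compound 2 to compound 3 (0.31 log units; beyond the scatter) and chloro in place of methoxy gives a 2.1-fold lower number from compound 1 to compound 3 (0.33 log units; beyond the scatter) in the same direction. Both chloro steps are modest and lie just beyond the scatter, yet they agree, so compound 3 holds the lowest number of the three, and compound 1 and compound 2 stand on the same side of it despite their very different chains. Nothing shown here gives a reason for this shift.

Since chloro replaces the oxygen and its chain together, the compounds shown cannot tell whether the lower number goes with chloro itself or simply with the loss of that oxygen, and a plain hydrogen, a fluoro or a bromo at this place would separate the two. They also leave open whether an amine or a carboxylic acid here would move the number further, and whether chloro would do the same on another carbon of the ring.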